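The compounds below may be only part of what the source reports. "The series", "measured", "known", "first", "only" and "open" are said of these compounds alone.

Measured in a functional assay on MGC-803 cells (Homo sapiens) for antiproliferative activity, read by MTT assay, with a stated time of 48 h; a higher number here means a weaker inhibitor, a lower number a stronger inhibitor:
compound 1 `COc1cc(N(Cc2ccc(C)cc2)C(=O)CSc2nc3ccccc3s2)cc(OC)c1OC` — 54200 nM
compound 2 `COc1ccc(CN(C(=O)CSc2nc3ccccc3s2)c2cc(OC)c(OC)c(OC)c2)cc1O` — 35 nM
compound 3 `COc1ccc(CN(C(=O)CSc2nc3ccccc3s2)c2cc(OC)c(OC)c(OC)c2)cc1F` — 416 nM

Compound 1 stands highest of the three in this assay; compound 3 is nearest and compound 2 furthest, both beyond the scatter. Compound 4 `COc1ccc(CN(C(=O)CSc2nc3ccccc3s2)c2cc(OC)c(OC)c(OC)c2)cc1C(F)(F)F` differs from compound 1 in one place: 4-methoxy-3-(trifluoromethyl)phenyl in place of 4-methylphenyl on a saturated chain carbon bound to an amide-type nitrogen. Among the measured compounds shown here, two measured steps bear on this change, both replacing the same 4-methylphenyl: a 1500-fold lower number from compound 1 to compound 2 (3.19 log units; beyond the scatter) and a 130-fold lower number from compound 1 to compound 3 (2.11 log units; beyond the scatter). Between those two products, a 12-fold higher number from compound 2 to compound 3 (1.08 log units; beyond the scatter) shows the hydroxy compound as the stronger inhibitor. The trifluoromethyl entering in compound 4 carries no hydrogen-bond donor, like the fluoro of compound 3, so a large drop is expected, closer to the smaller of the two steps: a 90-fold lower number from compound 1 to compound 4 (1.96 log units; beyond the scatter). Compound 4 is estimated at 600 nM, between 150 nM and 2500 nM.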

Compound 4, half-maximal inhibitory concentration: 25200 nM
The estimate for compound 4 lay 42-fold (1.62 log units) below the measured number; the whole stated range lies below it.
By their numbers in this assay, from the lowest: compound 2; then compound 3; then compound 4; then compound 1.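

In this assay, 4-methoxy-3-(trifluoromethyl)phenyl keeps little of the gain seen with the other two replacements of 4-methylphenyl (a 2.2-fold lower number from compound 1 to compound 4 (0.33 log units; beyond the scatter)). Trifluoromethyl is far poorer than fluoro (a 61-fold higher number from compound 3 to compound 4 (1.78 log units; beyond the scatter)) and poorer still than hydroxy (a 720-fold higher number from compound 2 to compound 4 (2.86 log units; beyond the scatter)). The lack of a hydrogen-bond donor therefore does not alone set the level, as the fluoro of compound 3 and the trifluoromethyl of compound 4 both lack one yet lie far apart.

As far as these compounds go, whether an amine or a carboxylic acid in place of the hydroxy of compound 2 would hold its level stays open. No measurement at hand explains these gaps.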